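Pyrazole carboxylic acid series: aryl change at the pyrazole carbon

This account rests on a few compounds, and the source may have more. Where it says the series, first, only, none or still open, it means among the compounds named here.

Three measured compounds frame the series. Compound 1 `CCSc1sc(-n2nc(C)c(Cc3ccccc3[N+](=O)[O-])c2C(=O)O)nc1-c1ccc(Cl)c(Cl)c1` gives 59000 nM in a functional assay on BJAB cells (Homo sapiens) for antiproliferative activity, with a stated time of 4 days; on this read-out higher numbers stand for an effect only at larger amounts of compound and lower numbers for an effect already at smaller amounts. Compound 2 `Cc1c(-c2cc(Cl)cc(Cl)c2)c(C(=O)O)nn1-c1nc(-c2cnn(C)c2)c(SC(C)C)s1` returns "not active" (no number reported) in this assay and so offers no number. Compound 3 `Cc1nn(-c2nc(-c3ccc(Cl)c(Cl)c3)c(SC(C)C)s2)c(C(=O)O)c1-c1cccc(F)c1` gives 900 nM in this assay, the lowest of the two numbers shown; its nearest neighbour in value, compound 1, lies beyond the scatter from it, and compound 1 and compound 2 both differ from compound 3 in more than one place, so no single step is available.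

Compound 4 `Cc1cc(C#N)cc(-c2c(C)nn(-c3nc(-c4ccc(Cl)c(Cl)c4)c(SC(C)C)s3)c2C(=O)O)c1` is the untested member. It differs from compound 3 as follows: 3-cyano-5-methylphenyl in place of 3-fluorophenyl on an aromatic carbon. For the measured compounds named here, no measured pair isolates this change, so its size is an open question. The working expectation is a moderate weakening from compound 3 to compound 4, of the order a 2.8-fold higher number from compound 3 to compound 4 (0.44 log units; beyond the scatter), since the nitrile and methyl together enlarge the aryl group without precedent in the measured set. For compound 4 the expected value in this assay is 2500 nM, with a range from 600 nM to 12000 nM.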

Compound 4, half-maximal effective concentration: 4800 nM
Compound 4: middle estimate off by 1.9-fold (0.28 log units), on the low side, and the stated range covers the measured number.
By their numbers in this assay, from the lowest: compound 3; then compound 4; then compound 1.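

This aromatic carbon, next to the ring atom that bears a carboxy group, now has its first single-place step: in this assay the change to 3-cyano-5-methylphenyl from 3-fluorophenyl gives a modest step beyond the scatter (a 5.3-fold higher number from compound 3 to compound 4 (0.73 log units; beyond the scatter)). The position therefore tolerates the larger aryl group with a numerical read-out retained, although the number rises and does not stay level. Nothing measured here explains the shift.

The compounds shown leave open which change accounts for the step: the loss of the fluorine, the entry of the nitrile, or the entry of the methyl, as all three occur together. Also open, from the compounds shown here alone, is how this position responds to an amine or a methoxy group on the same phenyl ring.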